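Series notes: compound 4 after the chloro-for-methyl swap

The compounds below may be only part of what the source reports. "The series", "measured", "known", "first", "only" and "open" are said of these compounds alone.

Three compounds share one core and differ only in the group on the saturated chain carbon bound to sulfur. Compound 1 `CC(C)CSc1n[nH]c(-n2[se]c3ccccc3c2=O)n1` gives 34900 nM in a functional assay on HeLa cells (Homo sapiens) for antiproliferative activity, read by CCK-8 assay, with a stated time of 48 h; on this read-out lower numbers stand for stronger inhibition and higher numbers for weaker inhibition. Compound 2 `CCCCCCSc1n[nH]c(-n2[se]c3ccccc3c2=O)n1` gives 35900 nM in this assay, and compound 3 `Cc1ccc(CSc2n[nH]c(-n3[se]c4ccccc4c3=O)n2)cc1` gives 34800 nM. The three steps are flat: a 1.0-fold higher number from compound 1 to compound 2 (0.01 log units; within the scatter), a 1.0-fold lower number from compound 1 to compound 3 (0.00 log units; within the scatter) and a 1.0-fold lower number from compound 2 to compound 3 (0.01 log units; within the scatter). Compound 3 has the lowest of the three numbers, but its gaps to compound 1 and compound 2 lie within the scatter, so no order among the three is established.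

Compound 4 `O=c1c2ccccc2[se]n1-c1nc(SCc2ccc(Cl)cc2)n[nH]1` is the next member. Relative to compound 3 the change is chloro in place of methyl on an aromatic carbon. For the measured compounds named here, no measured step alters a substituent on this aromatic ring; the three steps all vary the group on the saturated chain carbon bound to sulfur, and each stays within the scatter. They show the read-out insensitive to the nature of that group across isopropyl, pentyl and 4-methylphenyl, but say nothing direct about chloro in place of methyl.

Given this, the expected step is a 1.0-fold lower number from compound 3 to compound 4 (0.01 log units; within the scatter), none beyond the scatter. Compound 4 is estimated at 34000 nM in this assay, with a range of 15000 nM to 75000 nM.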

Compound 4, half-maximal inhibitory concentration: 40900 nM
For compound 4 the middle estimate is 1.2-fold (0.08 log units) below the measured one; measured number inside the range.
By their numbers in this assay, from the lowest: compounds 3, 1, 2 and 4 (each within the scatter of the next).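

Chloro in place of methyl is the first change on the aromatic ring itself, on an aromatic carbon para to a large group, and the read-out in this assay does not separate the two groups (a step of a 1.2-fold higher number from compound 3 to compound 4 (0.07 log units; within the scatter)). Against the saturated groups on the chain carbon bound to sulfur, 4-chlorophenyl also stays level (steps of a 1.1-fold higher number from compound 2 to compound 4 (0.06 log units; within the scatter) and a 1.2-fold higher number from compound 1 to compound 4 (0.07 log units; within the scatter)), so all four compounds now lie within the scatter of one another, and neither a change on the ring nor a change of the whole group on that carbon has moved the number. Nothing measured here offers a reason for this flatness.

As far as these compounds go, whether this ring position stays flat with a group of another kind, such as an amine, a carboxylic acid or a methoxy group, remains open, as does the effect of a much longer chain on the carbon bound to sulfur. Also open is whether any change to the shared core would move the number in this assay, given that every compound shown carries that core unchanged.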